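A few compounds are considered here, and "the series" means these few. Any claim that something is new, unique, unknown or untested is made for them only; others in the source may bear on it.

Working notes on the sulfonamide series. The shared core carries a bis(trifluoromethyl)phenyl sulfonamide on one end of a short diamine linker and a benzyl group on the other. In a functional assay on BE(2)-C cells (Homo sapiens) for inhibition, read by MTT assay, with a stated time of 72 h (a higher number here means a weaker inhibitor of growth, a lower number a stronger inhibitor of growth), compound 1 `CC(C)(C)c1ccc(CNCCCNS(=O)(=O)c2cc(C(F)(F)F)cc(C(F)(F)F)c2)cc1` gives 2500 nM, and compound 2 `O=S(=O)(NCCNCc1ccc(-c2ccccc2)cc1)c1cc(C(F)(F)F)cc(C(F)(F)F)c1`, which carries a biphenyl in place of the substituted benzyl and a linker one unit shorter, gives in this assay 2700 nM. Among the compounds with values here, the two numbers sit within the usual scatter of each other, so they give no ranking and no step to build on.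

Compound 3 `O=S(=O)(NCCCNCc1ccc(C(F)(F)F)cc1)c1cc(C(F)(F)F)cc(C(F)(F)F)c1` differs from compound 1 by one change, (trifluoromethyl in place of tert-butyl on an aromatic carbon). Within the data shown here, no measured pair shows what this exchange does here, so there is no basis for a direction. The step from compound 1 to compound 3 in this assay is expected to be a 1.2-fold higher number from compound 1 to compound 3 (0.08 log units; within the scatter), within the scatter. Compound 3 is estimated in this assay at 3000 nM, with a range from 1200 nM to 8000 nM.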

Compound 3, concentration for 50% growth inhibition: 2700 nM
For compound 3 the middle estimate is 1.1-fold (0.05 log units) above the measured one; measured number inside the range.
By their numbers in this assay, from the lowest: compounds 1, 2 and 3 (each within the scatter of the next).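

In this assay, the only exchange shown at this position, trifluoromethyl in place of tert-butyl on an aromatic carbon para to a large group, gives a 1.1-fold higher number from compound 1 to compound 3 (0.03 log units; within the scatter) and so does not separate the two groups. The position thus carries either group with no readable difference in growth inhibition, a finding that extends only to compound 1 and compound 3. No available data bear on why the two groups read alike.

Going by these compounds, whether a hydrogen, a methoxy group, an amine or a carboxylic acid at this position would give a number beyond the scatter remains open. Compound 2 differs from compound 1 in more than one place, so the separate contributions of the biphenyl and the shorter linker also stay unresolved.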